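Swapping a methylthiazole for phenyl on a shared core

This account rests on a few compounds, and the source may have more. Where it says the series, first, only, none or still open, it means among the compounds named here.

Measured so far:
- compound 1, `Nc1nc(-c2ccc(C3CC3)o2)nc2sc(Cc3ccccc3)cc12`: 861 nM
- compound 2, `Cc1csc(-c2nc(N)c3cc(Cc4ccccc4)sc3n2)n1`: 1490 nM
- compound 3, `Cc1nc(-c2nc(N)c3cc(Cc4ccccc4)sc3n2)cs1`: 263 nM

The three compounds share one core and differ only in the aromatic group attached to it. In a functional assay on CHO-K1 cells for antagonist activity at adenosine receptor A1 (Homo sapiens), read by a beta-galactosidase reporter and cAMP accumulation, with stated times of 15 min and 6 h (on this read-out higher numbers stand for weaker inhibition and lower numbers for stronger inhibition), compound 3 gives the lowest number of the three: the step of a 3.3-fold lower number from compound 1 to compound 3 (0.52 log units; beyond the scatter) and the step of a 5.7-fold lower number from compound 2 to compound 3 (0.75 log units; beyond the scatter) both lie beyond the scatter, while the step of a 1.7-fold higher number from compound 1 to compound 2 (0.24 log units; within the scatter) does not.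

Compound 4, `Nc1nc(-c2ccccc2)nc2sc(Cc3ccccc3)cc12`, carries phenyl in place of 2-methyl-1,3-thiazol-4-yl on an aromatic carbon. For the measured compounds named here, no measured step replaces this methylthiazole with a plain carbon ring, so the comparison rests on the fact that both alternatives to the methylthiazole in compound 3, in compound 1 and compound 2, gave higher numbers. Phenyl, with no hydrogen-bond acceptors, is expected to behave more like those alternatives than like compound 3, so a modest rise in the number is expected, of about a 3.0-fold higher number from compound 3 to compound 4 (0.48 log units; beyond the scatter). Compound 4 is therefore estimated at 800 nM in this assay, with a range from 250 nM to 2500 nM.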

Compound 4, inhibition constant: 151 nM
Compound 4: middle estimate off by 5.3-fold (0.72 log units), on the high side, and the stated range ends above it.
By their numbers in this assay, from the lowest: compounds 4 and 3 (each within the scatter of the next); then compounds 1 and 2 (each within the scatter of the next).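

In this assay, replacing 2-methyl-1,3-thiazol-4-yl with phenyl on this aromatic carbon gives a 1.7-fold lower number from compound 3 to compound 4 (0.24 log units; within the scatter), so a ring of carbon only, with no hydrogen-bond acceptors, does as well here as the best thiazole shown. Against the other two groups, phenyl gives a 9.9-fold lower number from compound 2 to compound 4 (0.99 log units; beyond the scatter) and a 5.7-fold lower number from compound 1 to compound 4 (0.76 log units; beyond the scatter), so ring nitrogen, sulfur or oxygen in this group is not required for a low number. No supporting measurement explains these differences.

On these data alone, it remains open whether a small group on the phenyl ring, such as fluorine or methoxy, would lower the number further or raise it. A pyridine ring or a non-aromatic ring such as cyclohexyl at this position is also untested among the compounds shown.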